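This account rests on a few compounds, and the source may have more. Where it says the series, first, only, none or still open, it means among the compounds named here.

Three compounds have been measured in an assay on B16-F10 cells for inhibition of Tyrosinase (Mus musculus), tested at 5 uM; on this read-out lower numbers stand for less inhibition and higher numbers for more inhibition at the one concentration tested (going by the name of the read-out):

compound 1 `CC(/C=C/C1=CCCCC1(C)C)=C\C=C\C(C)=C\COC(=O)c1cc(O)c(O)c(O)c1`: 49.6%
compound 2 `CC(/C=C/C1=CCCCC1(C)C)=C\C=C\C(C)=C\COC(=O)c1c(O)cccc1O`: 45.4%
compound 3 `COc1cccc(C(=O)OC/C=C(C)/C=C/C=C(C)/C=C/C2=CCCCC2(C)C)c1O`: 38.1%

All three share one core and differ only in the aromatic group on the carbonyl carbon. Compound 3 gives the lowest of the three numbers: the step of a number 11.5 percentage points lower from compound 1 to compound 3 (beyond the scatter) is beyond the scatter, while the step of a number 7.3 percentage points lower from compound 2 to compound 3 (within the scatter) is within it, and the step of a number 4.2 percentage points lower from compound 1 to compound 2 (within the scatter) is also within it. So the spread among these groups is modest at best.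

Compound 4 `COc1cc(O)c(C(=O)OC/C=C(C)/C=C/C=C(C)/C=C/C2=CCCCC2(C)C)c(O)c1` has not yet been measured. It differs from compound 3 in the same place as the other swaps: a group of 10 heavy atoms (7 carbon, 3 oxygen; one six-membered aromatic ring of carbon only) in place of a group of 9 heavy atoms (7 carbon, 2 oxygen; one six-membered aromatic ring of carbon only), on a carbonyl carbon. The entering group carries 2 hydrogen-bond donors and 3 hydrogen-bond acceptors, one more of each than the leaving group, which brings it closer in count to the group of compound 1. All three measured steps bear on this change, and the largest of them, a number 11.5 percentage points lower from compound 1 to compound 3 (beyond the scatter), was only modest. A small rise from compound 3 is therefore expected, most likely not beyond the scatter. Compound 4 is expected to give 44% (range 32% to 56%), meaning an expected step of a number 5.9 percentage points higher from compound 3 to compound 4 (within the scatter).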

Compound 4, a percentage reported as inhibition, at one concentration (the size of the read-out at that concentration, not a potency): 41.9%
For compound 4 the middle estimate is 2.1 percentage points above the measured one; low and high end bracket the measured number.
By their numbers in this assay, from the lowest: compounds 3, 4, 2 and 1 (each within the scatter of the next, the first and the last beyond it).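

In this assay, for the compounds shown here, methoxy in place of hydrogen on an aromatic carbon of the 2,6-dihydroxyphenyl group gives a number 3.5 percentage points lower from compound 2 to compound 4 (within the scatter) and is the first change in this set that adds a single group while leaving the rest of the molecule as it was. The other two swaps at the carbonyl carbon give a number 3.8 percentage points higher from compound 3 to compound 4 (within the scatter) and a number 7.7 percentage points lower from compound 1 to compound 4 (within the scatter) and therefore place compound 4 within the scatter of every earlier compound. Going by these compounds alone, compound 1 and compound 3 remain the only pair set apart by more than the scatter, and compound 4 falls in the gap between them without extending the range, so all four aromatic groups on this carbonyl carbon give similar numbers.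

Nothing available explains why these differently substituted groups give such close numbers. From the compounds shown here alone, it remains open whether an unsubstituted phenyl, or an aromatic group carrying an amine or a carboxylic acid instead of hydroxy and methoxy groups, would move the number beyond the scatter, and what replacing the ester oxygen of the shared core with an amide nitrogen would do.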